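Swapping a benzyl for a tert-butyl on the ring nitrogen

The source may hold more compounds than are shown below. What is called first, only, known or untested is meant among the compounds shown, and "the series" means these compounds.

Of the compounds shown here, three have been measured in a functional assay on Jurkat cells (Homo sapiens) for cytotoxicity, read by MTT assay, with a stated time of 72 h; a higher number here means a weaker inhibitor, a lower number a stronger inhibitor. Compound 1 `Cc1cn([C@@H]2C[C@H](c3ccccc3)N(Cc3ccccc3)O2)c(=O)[nH]c1=O` gives 19300 nM. Compound 2 `CN1O[C@@H](n2ccc(N)nc2=O)C[C@H]1c1ccccc1` reaches only a limit of the assay, > 100000 nM. Compound 3 `CN1O[C@@H](n2ccc(N)nc2=O)C[C@@H]1c1ccccc1` likewise reaches only a limit of the assay, > 100000 nM. Compound 1 therefore stands as the only one of the three with a readable number; the other two sit at the limit of > 100000 nM in this assay, at which 2 of the 3 values shown sit. The step that the two limits leave unreadable from compound 2 to compound 3 cannot be sized, since the fact that compounds 2 and 3 differ only in the configuration as drawn is all that separates them and both ends are limits.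

Compound 4 `Cc1cn([C@@H]2C[C@H](c3ccccc3)N(C(C)(C)C)O2)c(=O)[nH]c1=O` is compound 1 with tert-butyl in place of benzyl on an amine nitrogen in a ring. Among the compounds with values here, no measured step touches this position: the only step on record, the one from compound 2 to compound 3, concerns a stereocentre and is unreadable, and compounds 2 and 3 differ from compound 1 at the ring nitrogen and at the base as well, so their limits say nothing about benzyl against tert-butyl. Within the data shown here, with no step bearing on the change, no shift beyond the usual scatter is expected in this assay in either direction. Compound 4 is therefore expected to give about 19300 nM, within a range of 5000 nM to 80000 nM, which means an estimated step of no change at the digits printed from compound 1 to compound 4 (within the scatter).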

Compound 4, half-maximal inhibitory concentration: 72200 nM
Compound 4: the middle estimate sits 3.7-fold (0.57 log units) below what was measured, and the stated range covers the measured number.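

In this assay, the ring nitrogen now shows itself to be a position where the choice of group registers: tert-butyl in place of benzyl gives a 3.7-fold higher number from compound 1 to compound 4 (0.57 log units; beyond the scatter). Within the data shown here, this is the first readable step in the set, since the only earlier step could not be read, and it shows that benzyl gives the stronger result of this pair, although compound 1 and compound 4 both remain in the micromolar range. Among these compounds, nothing measured so far explains the difference, and the information on the other compounds does not bear on this change.

The swap alters two things at once, removing the six-membered aromatic ring and going from the 7 heavy atoms of benzyl to the 4 of tert-butyl, so this single pair cannot say which of the two matters. Cyclohexylmethyl, which is benzyl with its ring saturated, and phenethyl, which sets the same aromatic ring on a longer chain, would each separate these features, and how far the ring nitrogen tolerates other groups such as these remains open.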